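A few compounds are considered here, and "the series" means these few. Any claim that something is new, unique, unknown or untested is made for them only; others in the source may bear on it.

In a functional assay on HOP-62 cells (Homo sapiens) for inhibition, read by sulforhodamine B assay, with a stated time of 48 h (on this read-out lower numbers stand for stronger inhibition of growth and higher numbers for weaker inhibition of growth), two compounds sharing one core have been measured so far. Compound 1 `O=C(Cc1csc2nc(-c3ccc(Br)cc3)cn12)N/N=C/c1ccccc1O` gives 14800 nM, while compound 2 `O=C(Cc1csc2nc(-c3ccc(Br)cc3)cn12)N/N=C/c1ccc(O)cc1` gives 53700 nM, which makes compound 2 the higher of the two numbers and so the weaker inhibitor of growth.

The next structure, compound 3 `COc1cccc(OC)c1/C=N/NC(=O)Cc1csc2nc(-c3ccc(Br)cc3)cn12`, has 2,6-dimethoxyphenyl in place of 4-hydroxyphenyl on a carbon with a double bond to nitrogen.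

Within the data shown here, only one measured step bears on this change. That step, a 3.6-fold higher number from compound 1 to compound 2 (0.56 log units; beyond the scatter), exchanged 2-hydroxyphenyl for 4-hydroxyphenyl at the same place and was modest in size. Among the measured compounds shown here, it offers only a partial guide, as no measured compound here carries a methoxy group. For the measured compounds named here, since 4-hydroxyphenyl leaves in compound 3, and compound 2 holds the highest number so far, a modest move toward a lower number seems the likelier outcome in this assay, of no greater size than the measured step.

The expected change is a 2.1-fold lower number from compound 2 to compound 3 (0.32 log units; beyond the scatter).

For compound 3 the estimated value is 26000 nM, with an expected range from 9000 nM to 75000 nM.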

Compound 3, concentration for total growth inhibition: 30200 nM
Beside the measured number, compound 3's estimate is 1.2-fold (0.07 log units) below it; the range from low to high includes it.
By their numbers in this assay, from the lowest: compound 1; then compounds 3 and 2 (each within the scatter of the next).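

In this assay, placing 2,6-dimethoxyphenyl on the carbon with a double bond to nitrogen in place of 4-hydroxyphenyl gives a 1.8-fold lower number from compound 2 to compound 3 (0.25 log units; within the scatter), so the two compounds cannot be told apart on this read-out, even though the group that enters has no hydrogen-bond donor and the group that leaves has one. Against 2-hydroxyphenyl, the same exchange gives a 2.0-fold higher number from compound 1 to compound 3 (0.31 log units; beyond the scatter), which leaves compound 1 as the strongest inhibitor of growth of the three and shows that this position tolerates a larger group with two oxygens without a step beyond the scatter from compound 2. Nothing measured in the material at hand explains either step.

On these data alone, what remains open is whether the difference between compound 1 and compound 3 follows the loss of the hydroxy group or the arrival of the two methoxy groups, as both changes occur together in each step. The compounds shown also leave open how this position would respond to a plain phenyl group, or to a phenyl group carrying an amine or a carboxylic acid.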